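Amide-to-amine step on the aryl amine arm

This account rests on a few compounds, and the source may have more. Where it says the series, first, only, none or still open, it means among the compounds named here.

Going by the values given here, compound 1 `CC(C)CC(=O)Nc1cccc(-c2ccnc3c(C(=O)c4cccs4)cnn23)c1` gives 42 nM in a functional assay on DLD-1 cells (Homo sapiens) for antiproliferative activity (on this read-out higher numbers stand for weaker inhibition and lower numbers for stronger inhibition), the lowest of the two numbers so far. Compound 2 `CC(C)CNC(=O)c1cccc(-c2ccnc3c(C(=O)c4cccs4)cnn23)c1` gives 60 nM; the step of a 1.4-fold higher number from compound 1 to compound 2 (0.15 log units; within the scatter) lies within the scatter. Compound 3 `CC(C)CCNc1cccc(-c2ccnc3c(C(=O)c4cccs4)cnn23)c1` carries the change (isopentyl in place of isobutylcarbonyl on a nitrogen on an aromatic ring), that is (isobutylcarbonyl)amino to isopentylamino. Among the compounds with values here, no measured step removes the carbonyl; the single measured step, which moved the carbonyl and stayed within the scatter, is the only guide, so at most a modest weakening in this assay is expected. Compound 3 is estimated at 75 nM, range 25 nM to 220 nM, an expected step of a 1.8-fold higher number from compound 1 to compound 3 (0.25 log units; within the scatter).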

Compound 3, half-maximal inhibitory concentration: 120 nM
Compound 3: middle estimate off by 1.6-fold (0.20 log units), on the low side, within the range that was stated.
By their numbers in this assay, from the lowest: compounds 1, 2 and 3 (each within the scatter of the next, the first and the last beyond it).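

In this assay, going by these compounds alone, isopentyl in place of isobutylcarbonyl on the nitrogen gives the first step beyond the scatter, a 2.9-fold higher number from compound 1 to compound 3 (0.46 log units; beyond the scatter), so on these compounds the (isobutylcarbonyl)amino arm does not exchange freely for isopentylamino. Isopentylamino and the isobutylcarbamoyl arm, by contrast, remain within the scatter of each other, a 2.0-fold higher number from compound 2 to compound 3 (0.30 log units; within the scatter), so compound 2 and compound 3 cannot be ranked. Nothing on hand explains the step. Still open, on these data alone, is how a sulfonyl in place of the carbonyl, or a longer chain on this nitrogen, would read in this assay.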